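The source may report more compounds than this note shows. Statements on the series, on what has been measured and on what is new or still open speak of the compounds shown alone.

In a functional assay on KB cells (Homo sapiens) for antiproliferative activity, read by sulforhodamine B assay, with a stated time of 3 days (on this read-out lower numbers stand for an effect already at smaller amounts and higher numbers for an effect only at larger amounts of compound), compound 1 `CCC1=C(O)c2c(oc(-c3ccc(C(C)C)cc3)cc2=O)C(CC)(CC)C1=O` gives 8.13 uM, while compound 3 `CCC1=C(O)c2c(oc(-c3ccccc3OC)cc2=O)C(CC)(CC)C1=O` gives 40.8 uM, the higher of the two actual numbers. Compound 2 `CCC1=C(O)c2c(oc(-c3ccc(SC)cc3)cc2=O)C(CC)(CC)C1=O` gives only a limit, > 52.1 uM. Compound 4 `CCC1=C(O)c2c(oc(-c3ccc(OC)cc3C)cc2=O)C(CC)(CC)C1=O` has 4-methoxy-2-methylphenyl in place of the 2-methoxyphenyl of compound 3 (4-methoxy-2-methylphenyl in place of 2-methoxyphenyl on an aromatic carbon). Two measured steps change this same aromatic group. The clearer one is a 5.0-fold higher number from compound 1 to compound 3 (0.70 log units; beyond the scatter), which shows that this group can matter. The other, an at least 1.2-fold lower number from compound 2 to compound 3 (0.10 log units; that floor lies within the scatter), rests on a limit and gives little guidance. Neither step tests the new group directly, so only a small shift toward a lower number is expected: a 1.5-fold lower number from compound 3 to compound 4 (0.16 log units; within the scatter). For compound 4, the estimated value is 28 uM, with an expected range from 10 uM to 60 uM.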

Compound 4, concentration for half-maximal effect: 20.9 uM
The estimate for compound 4 lay 1.3-fold (0.13 log units) above the measured number, and the stated range covers the measured number.
By their numbers in this assay, from the lowest: compound 1; then compounds 4 and 3 (each within the scatter of the next). At a limit, above all of these: compound 2.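

In this assay, 4-methoxy-2-methylphenyl in place of 2-methoxyphenyl gives a 2.0-fold lower number from compound 3 to compound 4 (0.29 log units; within the scatter), so these two groups cannot be told apart here. Against 4-isopropylphenyl, the new group gives a 2.6-fold higher number from compound 1 to compound 4 (0.41 log units; beyond the scatter), so neither methoxy-bearing group shown matches it. Against 4-(methylsulfanyl)phenyl, it gives an at least 2.4-fold lower number from compound 2 to compound 4 (0.39 log units; beyond the scatter), a step that rests on a limit for compound 2, not a number: the limit of > 52.1 uM in this assay, at which 1 of the 4 values shown sits.

Still open, from the compounds shown here alone, is whether the isopropyl group itself or its place on the ring sets compound 1 apart. Going by these compounds, how a phenyl ring carrying an amine or a carboxylic acid would behave at this position also remains unknown.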